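The source may report more compounds than this note shows. Statements on the series, on what has been measured and on what is new or still open speak of the compounds shown alone.

In a functional assay on blood (Homo sapiens), with a stated time of 60 min, in the presence of a further agent that is not named here (a lower number here means that less compound is needed, a higher number that more compound is needed for the effect), compound 1 `O=C(O)C1(S(=O)(=O)c2ccc(Oc3ccc(OC(F)(F)F)cc3)cc2)CCC2(CCNCC2)C1` gives 1800 nM. Compound 2 `NC(=O)C1(S(=O)(=O)c2ccc(Oc3ccc(OC(F)(F)F)cc3)cc2)CCC2(CCNCC2)C1` gives 3700 nM in this assay, the highest of the two numbers, with compound 1 nearest: the step runs a 2.1-fold higher number from compound 1 to compound 2 (0.31 log units; beyond the scatter). Compound 3 `COc1ccc(N)c(NC(=O)C2(S(=O)(=O)c3ccc(Oc4ccc(OC(F)(F)F)cc4)cc3)CCC3(CCNCC3)C2)c1` carries 2-amino-5-methoxyphenyl in place of hydrogen on an amide-type nitrogen. Among the compounds with values here, no measured step bears directly on this change; the only known step, a 2.1-fold higher number from compound 1 to compound 2 (0.31 log units; beyond the scatter), exchanges the group on the carbonyl carbon and is modest, so it offers no direction for an aromatic ring entering on the amide-type nitrogen. For compound 3 a step of a 1.2-fold lower number from compound 2 to compound 3 (0.09 log units; within the scatter) is expected, with wide uncertainty. Compound 3 is estimated at 3000 nM, between 600 nM and 15000 nM.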

Compound 3, half-maximal effective concentration: 3700 nM
For compound 3 the middle estimate is 1.2-fold (0.09 log units) below the measured one, and the stated range covers the measured number.
By their numbers in this assay, from the lowest: compound 1; then compounds 2 and 3 (each within the scatter of the next).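

In this assay the amide-type nitrogen accepts 2-amino-5-methoxyphenyl in place of hydrogen with no shift in the number (no change at the digits printed from compound 2 to compound 3 (within the scatter)), so this position takes a large aromatic group without a visible penalty. Set against the hydroxy on the carbonyl carbon, (2-amino-5-methoxyphenyl)amino gives a modest step (a 2.1-fold higher number from compound 1 to compound 3 (0.31 log units; beyond the scatter)), of the same size as plain amino. No available evidence accounts for this result. Open, on these data alone, is whether the ring's amino or methoxy group matters at all, as an unsubstituted phenyl would show. Also open, as far as these compounds go, is how a hydroxamic acid on the carbonyl carbon would compare.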